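The source may hold more compounds than are shown below. What is called first, only, known or untested is meant among the compounds shown, and "the series" means these compounds.

Measured compounds:
Compound 1, `CCCCCC#Cc1cn([C@H]2C[C@H](O)[C@@H](CO)O2)c(=O)[nH]c1=O` — 219 ug/mL
Compound 2, `O=c1[nH]c(=O)n([C@H]2C[C@H](O)[C@@H](CO)O2)cc1C#CCCCO` — 280 ug/mL
Compound 3, `O=c1[nH]c(=O)n([C@H]2C[C@H](O)[C@@H](CO)O2)cc1C#CCO` — > 1000 ug/mL

In a functional assay on L1210 cells (Mus musculus) (a higher number here means a weaker inhibitor, a lower number a stronger inhibitor), compound 1 gives 219 ug/mL, and compound 2 gives 280 ug/mL. For compound 3 the assay reports only a limit, > 1000 ug/mL, the point at which (the limit of > 1000 ug/mL in this assay, at which 1 of the 3 values shown sits). The change ethyl in place of hydroxy on a saturated chain carbon, three bonds along the chain from a triple-bonded carbon makes a step of a 1.3-fold lower number from compound 2 to compound 1 (0.11 log units; within the scatter). Against that, an at least 4.5-fold higher number from compound 1 to compound 3 (0.65 log units; beyond the scatter) and an at least 3.5-fold higher number from compound 2 to compound 3 (0.55 log units; beyond the scatter), so compound 3 stands apart from the other two measured compounds.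

Compound 4, `CCCC#Cc1cn([C@H]2C[C@H](O)[C@@H](CO)O2)c(=O)[nH]c1=O`, has not yet been measured in this assay. It differs from compound 3 by ethyl in place of hydroxy on a saturated chain carbon bound to a triple-bonded carbon. For the measured compounds named here, this is the same kind of change as the one from compound 2 to compound 1, but the place differs: in the measured pair the change sits on a saturated chain carbon, three bonds along the chain from a triple-bonded carbon, whereas in the new pair it sits on a saturated chain carbon bound to a triple-bonded carbon. The cores of compound 2 and compound 3 differ by hydroxy in place of 2-hydroxyethyl on a saturated chain carbon bound to a triple-bonded carbon.

Since compound 3 gives only a limit, the step from compound 3 to compound 4 cannot be compared directly with the within-scatter step from compound 2 to compound 1. Compound 4 carries a chain of the same kind as compound 1, which gives 219 ug/mL, and compound 2, which gives 280 ug/mL, so compound 4 is expected to sit near those two rather than with compound 3, an expected step of an at least 3.5-fold lower number from compound 3 to compound 4 (0.55 log units; beyond the scatter). Compound 4 is therefore estimated at 280 ug/mL, in a range from 110 ug/mL to 800 ug/mL.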

Compound 4, concentration for 50% inhibition: > 1000 ug/mL
Compound 4: only a limit was reported; the forecaster's own chance of this, stated with the estimate: 15%; middle value at least 3.5-fold (0.55 log units) from the limit.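

In this assay compound 4 gives only a limit (> 1000 ug/mL). With hydrogen in place of hydroxy, the series shows an at least 3.5-fold higher number from compound 2 to compound 4 (0.55 log units; beyond the scatter), and with hydrogen in place of ethyl it shows an at least 4.5-fold higher number from compound 1 to compound 4 (0.65 log units; beyond the scatter), so compound 4 stands apart from both compounds and sits on the weak side of them, as far as the limit can say. Ethyl in place of hydroxy gave a 1.3-fold lower number from compound 2 to compound 1 (0.11 log units; within the scatter) on a saturated chain carbon, three bonds along the chain from a triple-bonded carbon, but this says nothing firm about the same change on a saturated chain carbon bound to a triple-bonded carbon: the step on that carbon cannot be read, and neither a carry-over nor a failure to carry over is shown, because compound 3 and compound 4 both stop at the same limit: the limit of > 1000 ug/mL in this assay, at which 2 of the 4 values shown sit.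

The compounds shown leave open how far beyond the limit compound 3 and compound 4 lie, and so whether hydroxymethyl and propyl differ at all in this assay. They also leave open whether an amine or a carboxylic acid at the end of the chain, or a chain longer than that of compound 1, would bring the number down or push it to the limit.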